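The source may report more compounds than this note shows. Statements on the series, on what has been measured and on what is new or still open speak of the compounds shown alone.

Series values in a functional assay on MCF7 cells (Homo sapiens) for inhibition, read by microscopy and colony formation, with a stated time of 10 days; on this read-out higher numbers stand for weaker inhibition and lower numbers for stronger inhibition:

- compound 1 `CCCCCCCCCCCCCCNC(=O)[C@H](CO)NCc1ccccc1`: 5000 nM
- compound 2 `CCCCCCCCCCCCCCNC(=O)[C@H](CO)NC(=O)c1cc(OC)cc(OC)c1`: 11200 nM

Compound 2 has the higher of the two numbers and is therefore the weaker inhibitor of the pair. The gap to compound 1 lies beyond the usual scatter.

The next compound is compound 3 `CCCCCCCCCCCCCCNC(=O)[C@H](CO)NC(C)=O`. It has methyl in place of 3,5-dimethoxyphenyl on a carbonyl carbon.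

Going by the values given here, no measured pair differs in one place only, so this exchange has no direct precedent. Among the compounds with values here, the only guide is the range set by compound 1 at 5000 nM and compound 2 at 11200 nM. In this assay, no change beyond the scatter is expected, and no direction is favoured: the estimated step is a 1.1-fold lower number from compound 2 to compound 3 (0.05 log units; within the scatter). For compound 3 the expected value is 10000 nM, with an estimated range of 3500 nM to 30000 nM.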

Compound 3, half-maximal inhibitory concentration: 44700 nM
Beside the measured number, compound 3's estimate is 4.5-fold (0.65 log units) below it; the whole stated range lies below it.
By their numbers in this assay, from the lowest: compound 1; then compound 2; then compound 3.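

On the carbonyl carbon, the exchange is not neutral: methyl in place of 3,5-dimethoxyphenyl gives a 4.0-fold higher number from compound 2 to compound 3 (0.60 log units; beyond the scatter) in this assay and so shows that this position responds to the group it carries. On the amine nitrogen, acetyl in place of benzyl gives an 8.9-fold higher number from compound 1 to compound 3 (0.95 log units; beyond the scatter) and leaves compound 3 as the weakest inhibitor of the three, with its steps to both others beyond the scatter. Nothing available accounts for either step, and their cause remains unassigned.

As far as these compounds go, whether the aromatic ring or the methoxy groups matter more on that carbonyl carbon remains open, and a plain phenyl or a longer alkyl chain there could separate the two. Also open, from the compounds shown here alone, is whether a carbonyl is needed at all, as an ethyl group on the amine nitrogen would show against the benzyl group.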